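Bromo to chloro step on compound 2

A few compounds are considered here, and "the series" means these few. Any claim that something is new, unique, unknown or untested is made for them only; others in the source may bear on it.

Values so far in a functional assay on HepG2 cells (Homo sapiens) for antiproliferative activity, read by MTT assay, with a stated time of 72 h; a lower number here means a stronger inhibitor, a higher number a weaker inhibitor
- compound 1 `COc1ccc(OCCCON2C(N)=NC(N)=NC23CCOCC3)cc1` with "not determined" (no result reported)
- compound 2 `NC1=NC2(CCSCC2)N(OCCCOc2ccc(Br)cc2)C(N)=N1` with 1400 nM

Within the data shown here, compound 2 stands at 1400 nM as the only number in the set, so it cannot be ranked. Compound 1 offers no number for comparison.

The next compound is compound 3 `NC1=NC2(CCSCC2)N(OCCCOc2ccc(Cl)cc2)C(N)=N1`, and its change from compound 2 is chloro in place of bromo on an aromatic carbon with chloro in place of bromo on an aromatic carbon, para to a large group. Among the measured compounds shown here, no measured step shows what such a swap does. In this assay the expectation is therefore no step beyond the scatter, in neither direction. An expected 1.1-fold higher number from compound 2 to compound 3 (0.03 log units; within the scatter) is estimated here. Compound 3 is estimated at 1500 nM with an expected range from 600 nM to 3500 nM in this assay.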

Compound 3, half-maximal inhibitory concentration: 1100 nM
For compound 3 the middle estimate is 1.4-fold (0.13 log units) above the measured one; the range from low to high includes it.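

In this assay, chloro in place of bromo on an aromatic carbon, para to a large group, gives a 1.3-fold lower number from compound 2 to compound 3 (0.10 log units; within the scatter). Among these compounds, this is the first measured step at this position, and it shows that the 4-bromophenoxy and 4-chlorophenoxy ends cannot be told apart in this assay, at least on the shared core of compound 2 and compound 3. Nothing measured bears on why the swap leaves the read-out within the scatter.

On these data alone, whether this position accepts anything other than a halogen stays open: an amine, a carboxylic acid or a nitrile at the same place would test that. Compound 1 has a methoxy group at this place but no number, so it adds nothing to the question.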